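This account rests on a few compounds, and the source may have more. Where it says the series, first, only, none or still open, it means among the compounds named here.

For the measured compounds named here, compound 2 `Cc1ccc2ncc(S(=O)(=O)c3ccc(C)c(F)c3)c(N3CCC(C)CC3)c2c1` has the higher of the two numbers measured so far: in an assay on isolated protein for displacement of a labelled ligand from metabotropic glutamate receptor 5 (Homo sapiens), with a stated time of 60 min, tested at 1 uM (on this read-out higher numbers stand for more inhibition at the one concentration tested (going by the name of the read-out) and lower numbers for less inhibition), compound 2 gives 91%. Compound 1 `COc1ccc(S(=O)(=O)c2cnc3ccc(C)cc3c2N2CCC(C)CC2)cc1`, which carries a 4-methoxyphenyl on the sulfonyl sulfur instead, gives 62% in this assay, and the step of a number 29 percentage points higher from compound 1 to compound 2 (beyond the scatter) is the only one measured. Compound 3 `COc1ccc(S(=O)(=O)c2cnc3ccc(C)cc3c2N2CCC(C)CC2)cc1Cl` is the next candidate; the change is 3-chloro-4-methoxyphenyl in place of 3-fluoro-4-methylphenyl on a sulfonyl sulfur. Going by the values given here, the one measured step bears on this directly, since compound 3 returns to a methoxy-bearing ring like that of compound 1, but now with a chlorine added to it. On these data alone, a drop back toward compound 1 therefore seems plausible, softened by the added chlorine, whose effect here is untested. The expected step is a number 19 percentage points lower from compound 2 to compound 3 (beyond the scatter). Compound 3 is estimated at 72%, within a range from 50% to 90%.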

Compound 3, a percentage reported as inhibition, at one concentration (the size of the read-out at that concentration, not a potency): 93%
Compound 3: middle estimate off by 21 percentage points, on the low side; the measured number lies above the stated range.
By their numbers in this assay, from the lowest: compound 1; then compounds 2 and 3 (each within the scatter of the next).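

In this assay, chloro in place of hydrogen on an aromatic carbon gives a number 31 percentage points higher from compound 1 to compound 3 (beyond the scatter), so on this ring a methoxy group does not have to go with the lower number seen for compound 1. With 3-chloro-4-methoxyphenyl in place of 3-fluoro-4-methylphenyl on a sulfonyl sulfur, the result is a number 2 percentage points higher from compound 2 to compound 3 (within the scatter), which means that these two differently substituted rings cannot be told apart on this read-out. Nothing available explains why the added chloro goes with this change.

On these data alone, whether a bromo or a nitrile in place of the chloro, or an ethoxy in place of the methoxy, would give a similar number remains open. A read-out at a single concentration also leaves open whether compound 2 and compound 3 differ in potency.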